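The source may report more compounds than this note shows. Statements on the series, on what has been measured and on what is new or still open speak of the compounds shown alone.

Working notes on the series. Compound 1 `Cn1c(-c2cccnc2)nc2ccc(F)cc21` is the smaller of two closely related members of this set; in an assay on V79 cells for inhibition of cytochrome P450 11B2, mitochondrial (Homo sapiens), read by HTRF, with a stated time of 1 h (on this read-out lower numbers stand for stronger inhibition and higher numbers for weaker inhibition), compound 1 gives 12 nM. Compound 2 `Cc1ccncc1-c1nc2cc(F)c(F)cc2n1C1CC1`, which carries a different substituent on the aromatic nitrogen together with further changes on both rings, in this assay gives 10.2 nM. The two values sit within the scatter of each other, so neither compound can be ranked against the other on the present numbers. Compound 3 `CCn1c(-c2cccnc2)nc2ccc(F)cc21` extends the chain on the aromatic nitrogen of compound 1: methyl in place of hydrogen on a saturated chain carbon bound to an aromatic nitrogen. Among the compounds with values here, no pair of measured compounds in this set differs only at that position, so the effect of the change has to be judged from the structural change itself and from the fact that both measured compounds sit at similar values despite different substituents on the aromatic nitrogen. The step of a 1.2-fold lower number from compound 1 to compound 3 (0.08 log units; within the scatter) is expected to stay within the scatter, with no clear direction. Compound 3 is therefore estimated to give 10 nM in this assay, within a range of 4 nM to 25 nM.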

Compound 3, half-maximal inhibitory concentration: 35 nM
The estimate for compound 3 lay 3.5-fold (0.54 log units) below the measured number; the whole stated range lies below it.
By their numbers in this assay, from the lowest: compounds 2 and 1 (each within the scatter of the next); then compound 3.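

In this assay, within the data shown here, the change from methyl to ethyl on the aromatic nitrogen gives a 2.9-fold higher number from compound 1 to compound 3 (0.46 log units; beyond the scatter) and so provides the first direct reading at this position. It shows that the position is not indifferent to chain size: a single added carbon, with no donor, acceptor or charge entering, is enough to move the number towards weaker inhibition by a modest step. No measurement available here accounts for this rise.

From the compounds shown here alone, a single step sets no trend, so it remains open whether a longer chain such as propyl would raise the number further, or whether a chain ending in an amine or a carboxylic acid would behave differently. Going by these compounds, the step also stands on the core of compound 1 alone, and whether it carries over to other substitution on that core remains open.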